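Chloro for fluoro on the styryl ring of a chalcone

The compounds below may be only part of what the source reports. "The series", "measured", "known", "first", "only" and "open" are said of these compounds alone.

Measured compounds:
compound 1, `Cc1ccc(COc2ccc(C(=O)/C=C/c3ccccc3)cc2)cc1`, 4%
compound 2, `Cc1ccc(COc2ccc(C(=O)/C=C/c3ccc(F)cc3)cc2)cc1`, "not determined" (no result reported)

Compound 1 carries an unsubstituted phenyl at the end of the enone, and in a functional assay on HCT-116 cells (Homo sapiens) for antiproliferative activity, read by sulforhodamine B assay, with a stated time of 3 days, tested at 25 uM (on this read-out lower numbers stand for a weaker effect and higher numbers for a stronger effect at the one concentration tested), compound 1 gives 4%, a weak effect at the one concentration tested. Compound 2, `Cc1ccc(COc2ccc(C(=O)/C=C/c3ccc(F)cc3)cc2)cc1`, bears a fluoro on that ring; in this assay compound 2 gives "not determined" (no result reported), so no single number places it on this read-out, and the step from compound 1 to compound 2 cannot be weighed.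

Compound 3, `Cc1ccc(COc2ccc(C(=O)/C=C/c3ccc(Cl)cc3)cc2)cc1`, differs from compound 2 by one counted change: chloro in place of fluoro on an aromatic carbon. Nothing measured here speaks to the size of such a swap on this read-out. Since compound 1 gives 4%, the expectation for compound 3 in this assay is a step that stays within the scatter, without a clear direction.

The estimate for compound 3 in this assay is therefore 8%, expected to fall between 0% and 25%.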

Compound 3, a percentage reported as inhibition, at one concentration (the size of the read-out at that concentration, not a potency): 12.3%
Compound 3: the middle estimate sits 4.3 percentage points below what was measured; the measured number falls inside the stated range.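

Among the compounds shown here, the chloro compound gives the first readable step at this position: in this assay, putting a chloro on the otherwise unsubstituted phenyl gives a number 8.3 percentage points higher from compound 1 to compound 3 (within the scatter), so this one substitution does not move the effect at the one concentration tested beyond the usual scatter. Compound 2 has no single number on this read-out, so the steps that involve it cannot be read, and the swap of fluoro for chloro, 4-fluorophenyl to 4-chlorophenyl, remains unsized. No measured property or other supporting information bears on this result.

The compounds shown leave open whether a different group at this position, such as an amine, a carboxylic acid or a longer chain, would produce a step beyond the scatter. They also leave open whether replacing the methyl group elsewhere on the core of compound 1 with a carboxylic acid would change the read-out, and a single-concentration percentage gives no potency for any of these compounds.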